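The source may hold more compounds than are shown below. What is called first, only, known or untested is meant among the compounds shown, and "the series" means these compounds.

Compound 1 `Nc1cccc(Nc2nc(N/N=C/c3ccc(F)cc3)ncc2Cl)c1`, compound 2 `C=CC(=O)Nc1cccc(Nc2nc(N/N=C/c3ccc(F)cc3)ncc2Cl)c1` and compound 3 `COc1ccc(/C=N/Nc2ncc(Cl)c(Nc3cccc(NC(=O)/C=C/CN(C)C)c3)n2)cc1` share one core and differ in the groups attached to it. In an ADME assay on HT-29 cells (Homo sapiens) for inhibition, read by MTT assay, with a stated time of 72 h (a higher number here means a weaker inhibitor, a lower number a stronger inhibitor), compound 1 gives 12300 nM. In the same assay compound 2 gives 6340 nM, and compound 3 gives 4820 nM. Compound 3 therefore carries the lowest of the three numbers; its gap to compound 2 lies within the usual scatter, while its gap to compound 1 lies beyond it. Among the compounds with values here, the only step measured between two compounds that differ in one place is a 1.9-fold lower number from compound 1 to compound 2 (0.29 log units; within the scatter), and it concerns a vinylcarbonyl replacing a hydrogen on a nitrogen, a change unrelated to the one now considered.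

Compound 4 `C/C(=N\Nc1ncc(Cl)c(Nc2cccc(NC(=O)/C=C/CN(C)C)c2)n1)c1ccncc1` differs from compound 3 in a single place: a group of 9 heavy atoms (7 carbon, 2 nitrogen; one six-membered aromatic ring with 1 hetero atom) in place of a group of 10 heavy atoms (8 carbon, 1 nitrogen, 1 oxygen; one six-membered aromatic ring of carbon only), on a nitrogen on an aromatic ring. Within the data shown here, no measured step in this set touches this kind of exchange, so there is nothing to suggest movement in either direction, and no change beyond the scatter is expected. Compound 4 is therefore estimated at 4800 nM in this assay, with a plausible range from 1500 nM to 15000 nM. The step of a 1.0-fold lower number from compound 3 to compound 4 (0.00 log units; within the scatter) that this estimate implies is expected to stay within the scatter.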

Compound 4, half-maximal inhibitory concentration: 10900 nM
Compound 4: middle estimate off by 2.3-fold (0.36 log units), on the low side; measured number inside the range.
By their numbers in this assay, from the lowest: compounds 3, 2, 4 and 1 (each within the scatter of the next, the first and the last beyond it).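

Compound 3 and compound 4 show that the number in this assay can respond to the group held on a nitrogen on an aromatic ring, which the earlier comparison could not show: a 2.3-fold higher number from compound 3 to compound 4 (0.35 log units; beyond the scatter). That makes compound 4 the weaker inhibitor of this pair, but the step is modest and lies only a little beyond the usual scatter, so this position shows a small sensitivity to this exchange, not a steep one. The whole group changes at once, so the six-membered aromatic ring with 1 hetero atom arrives together with every other difference in the group, and nothing available links the step to any single part of the exchange or offers a measured explanation for it.

The compounds shown leave open which part of the exchange carries the step, and how a plain phenyl ring or a saturated piperidine ring would read at this place. They also leave open whether the same exchange would give a similar step in a compound carrying the simpler vinylcarbonyl group of compound 2 instead of the longer dimethylamino chain.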